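The source may report more compounds than this note shows. Statements on the series, on what has been measured and on what is new or still open speak of the compounds shown alone.

In a functional assay on NUGC-3 cells (Homo sapiens) for antiproliferative activity, read by sulforhodamine B assay (on this read-out higher numbers stand for weaker inhibition of growth and lower numbers for stronger inhibition of growth), compound 3 `CCCCOc1cccc(O)c1C(=O)/C=C/c1ccc(O)cc1` gives > 30000 nM as its reading, and this is a limit, not a number. Compound 1 `CCCCCCOc1cccc(O)c1C(=O)/C=C/c1ccc(O)cc1` gives > 30000 nM as its reading, again a limit. Compound 2 `O=C(/C=C/c1ccc(O)cc1)c1c(O)cccc1OCC1CCCCC1` gives > 30000 nM as its reading, also a limit. The three readings thus share one limit (the limit of > 30000 nM in this assay, at which 3 of the 3 values shown sit).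

Compound 4 `O=C(/C=C/c1ccc(O)cc1)c1c(O)cccc1OCc1ccccc1` differs from compound 3 by phenyl in place of propyl on a saturated chain carbon bound to an oxygen on an aromatic ring and so reads butoxy to benzyloxy, with phenyl in place of propyl. Three measured changes on this chain bear on it: a step that the two limits leave unreadable from compound 1 to compound 2 together with a step that the two limits leave unreadable from compound 2 to compound 3 and a step that the two limits leave unreadable from compound 1 to compound 3 so none of them offers a size to carry over. For the measured compounds named here, no definite step in this assay can therefore be expected, and the likeliest outcome is another limit. Compound 4 is expected near 30000 nM with an estimated range from 12000 nM to 60000 nM if a number is reported at all. That estimate means an expected a number no higher from compound 3 to compound 4 (the limit leaves the size open) and no more than that.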

Compound 4, concentration for 50% growth inhibition: > 30000 nM
Compound 4: no number, only a limit (the forecaster's own chance of this, stated with the estimate: 75%); the middle value sits exactly at the limit.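

Compound 4 stops at the same limit as compound 1, compound 2 and compound 3, so no step between it and any of them can be read: the limit of > 30000 nM in this assay, at which 4 of the 4 values shown sit.

The compounds shown leave open how strongly any of the four inhibits growth, and whether exchanging these groups changes it at all.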